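A few compounds are considered here, and "the series" means these few. Any claim that something is new, unique, unknown or untested is made for them only; others in the source may bear on it.

In a functional assay on HCT-116 cells (Homo sapiens) for cytotoxicity, read by MTT assay, with a stated time of 72 h (a higher number here means a weaker inhibitor, a lower number a stronger inhibitor), compound 1 (`COc1ccc(S(=O)(=O)c2nc3ccccc3nc2N2CCCC(O)C2)cc1`) gives 3520 nM and compound 2 (`Cc1ccc(S(=O)(=O)c2nc3ccccc3nc2N2CCC(O)CC2)cc1`) gives 5440 nM as the other of the two numbers, the pair lying within the scatter of each other. Compound 3 (`COc1ccc(S(=O)(=O)c2nc3ccccc3nc2N2CCC(O)CC2)cc1`) has yet to be measured. It differs from compound 2 at one place (methoxy in place of methyl on an aromatic carbon): methoxy in place of methyl on an aromatic carbon, the change from 4-methylphenyl to 4-methoxyphenyl. Among the compounds with values here, no measured pair isolates this change. The 4-methoxyphenyl group already stands in compound 1 at 3520 nM without leaving the scatter around compound 2. No step beyond the scatter is therefore expected in this assay and no firm direction can be given. The expected step runs a 1.2-fold lower number from compound 2 to compound 3 (0.08 log units; within the scatter) and stays within the scatter. For compound 3 the expected value is 4500 nM within an estimated span of 1800 nM to 11000 nM in this read-out.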

Compound 3, half-maximal inhibitory concentration: 4690 nM
For compound 3 the middle estimate is 1.0-fold (0.02 log units) below the measured one, and the stated range covers the measured number.
By their numbers in this assay, from the lowest: compounds 1, 3 and 2 (each within the scatter of the next).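

In this assay, methoxy in place of methyl on an aromatic carbon, para to a large group, now has a matched reading: a 1.2-fold lower number from compound 2 to compound 3 (0.06 log units; within the scatter). With the 4-methoxyphenyl group held constant, 4-hydroxypiperidin-1-yl in place of 3-hydroxypiperidin-1-yl also has its own reading, a 1.3-fold higher number from compound 1 to compound 3 (0.12 log units; within the scatter), so the two places in which compound 1 and compound 2 differ can now be read separately, and neither change alone separates the compounds beyond the scatter. No available evidence bears on these results.

On these data alone, whether a carboxylic acid or an amine at this place on the aromatic ring would give a step beyond the scatter remains open. Also open, as far as these compounds go, is whether replacing the hydroxyl on the piperidine with a methoxy or an amine would do so.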